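The source may hold more compounds than are shown below. What is called first, only, known or untested is meant among the compounds shown, and "the series" means these compounds.

Measured in an assay on frontal cortex for displacement of a labelled ligand from corticotropin-releasing factor receptor 1 (Rattus norvegicus), with a stated time of 2 h; on this read-out higher numbers stand for weaker inhibition and lower numbers for stronger inhibition:
- compound 1, `COc1nc(C)c(Nc2nc(Cl)cn([C@H](COC(C)=O)C3CC3)c2=O)cc1C`, compound 1 gives 5.3 nM
- compound 2, `COc1nc(C)c(Nc2nc(Cl)cn([C@H](COC(=O)Nc3ccccc3)C3CC3)c2=O)cc1C`, compound 2 gives 1.5 nM
- compound 3, `CCNC(=O)OC[C@H](C1CC1)n1cc(Cl)nc(Nc2cc(C)c(OC)nc2C)c1=O`, compound 3 gives 14 nM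

Compound 2 holds the lowest number of the three; its nearest neighbour is compound 1, with a 3.5-fold lower number from compound 1 to compound 2 (0.55 log units; beyond the scatter) separating them, and compound 3 lies furthest, with a 9.3-fold higher number from compound 2 to compound 3 (0.97 log units; beyond the scatter). Compound 4 is `COc1nc(C)c(Nc2nc(Cl)cn([C@H](COc3cccnc3)C3CC3)c2=O)cc1C`. It differs from compound 2 by pyridin-3-yl in place of phenylcarbamoyl on an oxygen on a saturated carbon. Among the measured compounds shown here, two measured steps bear on this change: a 3.5-fold lower number from compound 1 to compound 2 (0.55 log units; beyond the scatter) and a 9.3-fold higher number from compound 2 to compound 3 (0.97 log units; beyond the scatter), both of which turn on what stands on the carbamate terminus and both modest. Compound 4 keeps an aromatic ring on that oxygen but drops the phenylcarbamoyl entirely, so a modest step upward in this assay is expected, roughly a 3.3-fold higher number from compound 2 to compound 4 (0.52 log units; beyond the scatter). For compound 4 the estimate is 5 nM, expected between 1.5 nM and 16 nM.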

Compound 4, half-maximal inhibitory concentration: 6.7 nM
Compound 4: the middle estimate sits 1.3-fold (0.13 log units) below what was measured; the measured number falls inside the stated range.
By their numbers in this assay, from the lowest: compound 2; then compounds 1 and 4 (each within the scatter of the next); then compound 3.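

In this assay, with a 1.3-fold higher number from compound 1 to compound 4 (0.10 log units; within the scatter) as the step, (pyridin-3-yl)oxy matches the acetyl ester on this carbon, so a carbonyl on the oxygen is not required in this set. Compound 4 falls inside the carbamate span, with a 4.5-fold higher number from compound 2 to compound 4 (0.65 log units; beyond the scatter) as the step against phenylcarbamoyl and a 2.1-fold lower number from compound 3 to compound 4 (0.32 log units; beyond the scatter) as the step against ethylcarbamoyl, and phenylcarbamoyl keeps the lowest number. Nothing available explains these differences. Going by these compounds, the role of the ring nitrogen remains open: a plain phenyl, pyridin-2-yl or pyridin-4-yl on the same oxygen would address it.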